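The compounds below may be only part of what the source reports. "The series", "measured", "known", "first", "only" and "open" are said of these compounds alone.

Compound 3 `O=C(CCC1CCCC1)NNc1c(Cl)cncc1Cl` — 380 nM
Compound 1 `O=C(CCc1ccc(F)cc1)NNc1c(Cl)cncc1Cl` — 900 nM
Compound 2 `Cc1ccc(CCC(=O)NNc2c(Cl)cncc2Cl)cc1` — 1400 nM

In a functional assay on HEK293 cells for antagonist activity at P2X purinoceptor 7 (Homo sapiens), read by fluorescence, with a stated time of 2 h (a lower number here means a stronger inhibitor, a higher number a weaker inhibitor), compound 3 stands at the lowest of the three numbers: the step of a 2.4-fold lower number from compound 1 to compound 3 (0.37 log units; beyond the scatter) and the step of a 3.7-fold lower number from compound 2 to compound 3 (0.57 log units; beyond the scatter) both lie beyond the scatter, while a 1.6-fold higher number from compound 1 to compound 2 (0.19 log units; within the scatter) stays within it. Compound 4 `O=C(CC1CCCCC1)NNc1c(Cl)cncc1Cl` differs from compound 3 in one place: cyclohexyl in place of cyclopentylmethyl on a saturated chain carbon bound to a carbonyl carbon. Among the compounds with values here, no measured step exchanges one saturated ring for another; the two steps into compound 3 show only that a cycloalkyl on this chain carbon gives lower numbers than either aryl. The step from compound 3 to compound 4 is therefore expected to be small, a 1.2-fold higher number from compound 3 to compound 4 (0.07 log units; within the scatter), with no sure direction. For compound 4 the estimate is 450 nM, with a range from 150 nM to 1400 nM.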

Compound 4, half-maximal inhibitory concentration: 730 nM
Estimate against measurement, compound 4: 1.6-fold (0.21 log units) below; low and high end bracket the measured number.
By their numbers in this assay, from the lowest: compounds 3, 4, 1 and 2 (each within the scatter of the next, the first and the last beyond it).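

In this assay, cyclohexyl in place of cyclopentylmethyl on the saturated chain carbon bound to a carbonyl carbon gives a 1.9-fold higher number from compound 3 to compound 4 (0.28 log units; within the scatter). Unlike the earlier steps, which exchanged an aryl group for a cycloalkyl group or one aryl substituent for another, this one exchanges one saturated carbon ring group for another with the same heavy-atom count, and the change stays within the scatter. No measurement bears on the reason for this result.

Going by these compounds, whether an amine or a carboxylic acid on the saturated ring would be accepted remains open. So does the effect of a longer chain between the ring and the carbonyl.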